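Replacing the Benzothiazole Amide of Compound 2 with a Urea

The source may hold more compounds than are shown below. What is called first, only, known or untested is meant among the compounds shown, and "the series" means these compounds.

Of the compounds shown here, three sharing one core have been measured in an assay on THP-1 cells for displacement of a labelled ligand from C-C chemokine receptor type 1 (Homo sapiens); on this read-out lower numbers stand for stronger inhibition and higher numbers for weaker inhibition. Compound 2 `CC(C)[C@@H](NC(=O)c1nc2ccccc2s1)C(=O)N1CCC(c2ccc(Cl)cc2)CC1` gives 18 nM, the lowest number of the three. Compound 3 `Cc1ccccc1C(=O)NC(CC(C)C)C(=O)N1CCC(c2ccc(Cl)cc2)CC1` gives 88 nM, and compound 1 `CC(C)C(NS(=O)(=O)Cc1ccccc1)C(=O)N1CCC(c2ccc(Cl)cc2)CC1` gives 303 nM; both gaps to compound 2 lie beyond the usual scatter of this assay, so compound 2 stands as the most potent of the set on these numbers.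

Compound 4 `CC(C)[C@@H](NC(=O)Nc1ccccc1)C(=O)N1CCC(c2ccc(Cl)cc2)CC1` has not been measured. It differs from compound 2 in one place: anilino in place of 1,3-benzothiazol-2-yl on a carbonyl carbon. The carbonyl carbon that carries the new group keeps its amide-type nitrogen neighbour, so the change turns the acyl amide of compound 2 into a urea.

Going by the values given here, no measured pair shows this exact change, so the expectation rests on compound 2 alone and on the spread of the other two values. Compound 4 is expected to remain a reasonably strong binder, though a moderate loss against compound 2 is expected, with the step from a 3.3-fold higher number from compound 2 to compound 4 (0.52 log units; beyond the scatter) judged likely to fall somewhat beyond the scatter. The estimate for compound 4 in this assay is 60 nM, with a range from 15 nM to 250 nM.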

Compound 4, half-maximal inhibitory concentration: 616 nM
Estimate against measurement, compound 4: 10-fold (1.01 log units) below, outside the stated range (above it).
By their numbers in this assay, from the lowest: compound 2; then compound 3; then compound 1; then compound 4.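

In this assay, the group on this carbonyl carbon proves to matter strongly: anilino in place of 1,3-benzothiazol-2-yl gives a 34-fold higher number from compound 2 to compound 4 (1.53 log units; beyond the scatter), a large step. The earlier compounds shown here differ from one another in more than one place and could not isolate any single group, whereas this pair holds everything else constant and ties the whole step to this one change. The change removes a five-membered aromatic ring with its sulfur and adds a hydrogen-bond donor, but no measurement shows which difference matters or explains the loss.

From the compounds shown here alone, it remains open whether the loss follows from the urea linkage or from losing the 1,3-benzothiazol-2-yl group itself; a plain phenyl directly on the carbonyl carbon, giving an amide, and a 1,3-benzothiazol-2-ylamino group, giving a urea, would separate the two. Also open, going by these compounds, is whether a urea at this position can regain binding with another group on its nitrogen, such as a benzylamino, a cyclohexylamino or an N-methylanilino group.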